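Adding a chloro group to compound 2

The source may hold more compounds than are shown below. What is called first, only, known or untested is meant among the compounds shown, and "the series" means these compounds.

Measured in a functional assay on IGROV-1 cells (Homo sapiens) for inhibition, with a stated time of 48 h; on this read-out lower numbers stand for stronger inhibition of growth and higher numbers for weaker inhibition of growth:
compound 1 `COc1c(C(=O)/C=C/c2ccc(Cl)cc2)c(O)c(Br)c2occc12` gives 3040 nM
compound 2 `C=CCc1c(O)c(C(=O)/C=C/c2ccccc2)c(OC)c2ccoc12` gives 3350 nM

Compound 2 stands level with compound 1, as their two values lie within the usual scatter of each other. Compound 3 `C=CCc1c(O)c(C(=O)/C=C/c2ccc(Cl)cc2)c(OC)c2ccoc12` differs from compound 2 in one place, with chloro in place of hydrogen on an aromatic carbon, so phenyl becomes 4-chlorophenyl (chloro in place of hydrogen on an aromatic carbon). For the measured compounds named here, no measured pair shows this change alone. Compound 1 carries 4-chlorophenyl on a core that differs elsewhere, and compound 1 still gives 3040 nM in this assay, close to compound 2. The expected change is therefore none beyond the scatter, an estimated 1.2-fold lower number from compound 2 to compound 3 (0.08 log units; within the scatter) in this assay. Compound 3 is estimated at 2800 nM (range 1300 nM to 5500 nM).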

Compound 3, concentration for 50% growth inhibition: 3460 nM
Compound 3: middle estimate off by 1.2-fold (0.09 log units), on the low side, within the range that was stated.
By their numbers in this assay, from the lowest: compounds 1, 2 and 3 (each within the scatter of the next).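

In this assay, chloro in place of hydrogen on the aromatic carbon gives a 1.0-fold higher number from compound 2 to compound 3 (0.01 log units; within the scatter), so phenyl and 4-chlorophenyl stand level on this core. Allyl in place of bromo on an aromatic carbon gives a 1.1-fold higher number from compound 1 to compound 3 (0.06 log units; within the scatter), so this change also leaves the growth-inhibition values level. No supporting measurement is available to explain either result. The compounds shown leave open whether an amine or a carboxylic acid in place of chloro, or a longer chain in place of allyl, would shift the value beyond the scatter.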